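Trading dimethylamino for azetidin-1-yl on compound 1

The source may hold more compounds than are shown below. What is called first, only, known or untested is meant among the compounds shown, and "the series" means these compounds.

- Compound 1 `C[C@@H](CO)Oc1cc(Oc2ccc(C(=O)N(C)C)cc2)cc(C(=O)Nc2ccn(C)n2)c1` gives 78%
- Compound 2 `COC[C@H](C)Oc1cc(Oc2ccc(C(=O)N(C)C)cc2)cc(C(=O)Nc2cc[nH]n2)c1` gives 27%

In an ADME assay on the whole organism for pharmacokinetics, with Rattus norvegicus as the target (on this read-out higher numbers stand for higher oral bioavailability and lower numbers for lower oral bioavailability), compound 1 stands highest of the two measured compounds, and compound 2 lies lower by more than the usual scatter. These two differ in more than one place, so they do not show what any single change does.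

Compound 3 `C[C@@H](CO)Oc1cc(Oc2ccc(C(=O)N3CCC3)cc2)cc(C(=O)Nc2ccn(C)n2)c1` differs from compound 1 in one place only, with azetidin-1-yl in place of dimethylamino on a carbonyl carbon. For the measured compounds named here, no measured pair shows this change on its own, so the expectation starts from compound 1 at 78% and allows wide uncertainty. A small drop in this assay is expected, and the estimated step of a number 8 percentage points lower from compound 1 to compound 3 (within the scatter) stays within the usual scatter. For compound 3 the estimated value is 70% with an expected range of 45% to 90% once measured.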

Compound 3, oral bioavailability in the Rattus norvegicus assay: 30%
Compound 3: middle estimate off by 40 percentage points, on the high side, outside the stated range (below it).
By their numbers in the Rattus norvegicus assay, from the lowest: compounds 2 and 3 (each within the scatter of the next); then compound 1.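

In the Rattus norvegicus assay, this carbonyl substituent proves far from a silent spot: compound 1 gives 78% and compound 3 gives 30%, so azetidin-1-yl in place of dimethylamino gives a number 48 percentage points lower from compound 1 to compound 3 (beyond the scatter), even though the change adds no hydrogen-bond donor or acceptor and no net charge. For the compounds shown here, in a physicochemical assay for lipophilicity (a higher number here means a more lipophilic compound, a lower number a more polar compound), compound 1 gives 1.7 and compound 3 gives 1.8, and the same change gives a number 0.10 log units higher from compound 1 to compound 3 (within the scatter), so the large step in the whole animal comes with no matching step on that scale. Nothing available here accounts for the drop.

From the compounds shown here alone, what stays open is whether the loss belongs to the four-membered ring in particular or would follow any ring closed on this carbonyl carbon. A pyrrolidin-1-yl or a diethylamino group at the same place, on the core of compound 1, would help to separate those two readings.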